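Aryl sulfonyl variation on the shared core

The compounds below may be only part of what the source reports. "The series", "measured", "known", "first", "only" and "open" are said of these compounds alone.

Two measured compounds share one core. Going by the values given here, compound 1 `CCOc1nc2ccccn2c(=N)c1S(=O)(=O)c1ccccc1` and compound 2 `CSc1nc2ccccn2c(=N)c1S(=O)(=O)c1ccc(F)cc1` differ from each other in more than one place, so no single step between them is given. In an assay on HeLa cells for displacement of a labelled ligand from 5-hydroxytryptamine receptor 6 (Homo sapiens) (on this read-out lower numbers stand for stronger inhibition and higher numbers for weaker inhibition), compound 1 gives 12 nM. In this assay compound 2 gives 22 nM, the higher of the two numbers, though the two values lie within the scatter of each other and no order between them is claimed.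

Compound 3 `CSc1nc2ccccn2c(=N)c1S(=O)(=O)c1ccccc1Cl` is not yet measured. It differs from compound 2 by 2-chlorophenyl in place of 4-fluorophenyl on a sulfonyl sulfur. Among the compounds with values here, no pair of measured compounds shows this change, so nothing here tells its size or direction in this assay; a step beyond the scatter in either direction cannot be ruled out, and the default expectation is none beyond it. Compound 3 is expected to give about 30 nM, within a range of 10 nM to 100 nM. The step that this estimate means is expected to be a 1.4-fold higher number from compound 2 to compound 3 (0.13 log units; within the scatter).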

Compound 3, half-maximal inhibitory concentration: 11 nM
For compound 3 the middle estimate is 2.7-fold (0.44 log units) above the measured one; measured number inside the range.
By their numbers in this assay, from the lowest: compounds 3, 1 and 2 (each within the scatter of the next).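

In this assay, 2-chlorophenyl in place of 4-fluorophenyl on a sulfonyl sulfur gives a 2.0-fold lower number from compound 2 to compound 3 (0.30 log units; within the scatter). Going by these compounds alone, this is the only step so far that isolates the aryl group on the sulfonyl sulfur, which the pair of compound 1 and compound 2 could not do because they differ in more than one place. For this one pair, the change of halogen and of its place on the phenyl ring produces no step beyond the scatter, and nothing available here offers an explanation for the size of that step.

The compounds shown leave open whether this position accepts anything other than a halogenated phenyl ring, such as a longer alkyl chain on the sulfonyl sulfur. On these data alone, an amine or a carboxylic acid on the phenyl ring is equally open.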